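This account rests on a few compounds, and the source may have more. Where it says the series, first, only, none or still open, it means among the compounds named here.

In a functional assay on MDA-MB-231 cells (Homo sapiens), read by microscopy and transwell migration, with a stated time of 24 h (on this read-out lower numbers stand for stronger inhibition and higher numbers for weaker inhibition), three compounds with a shared core and the same 2,4-dimethylphenyl group differ only in the chain on the ring nitrogen. Compound 1 (`CCCn1c(-c2ccc(C)cc2C)cs/c1=N\C(=O)c1ccccc1`) gives 292 nM, compound 2 (`CCCCCCCCCCCCn1c(-c2ccc(C)cc2C)cs/c1=N\C(=O)c1ccccc1`) gives 24 nM, and compound 3 (`C#CCn1c(-c2ccc(C)cc2C)cs/c1=N\C(=O)c1ccccc1`), which bears a propargyl group, gives 3890 nM. That is the highest of the three numbers, so compound 3 is the weakest inhibitor among them.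

Compound 4 (`C#CCn1c(-c2ccccc2)cs/c1=N\C(=O)c1ccccc1`) keeps the propargyl group and carries phenyl in place of 2,4-dimethylphenyl on an aromatic carbon.

The measured steps are a 12-fold lower number from compound 1 to compound 2 (1.09 log units; beyond the scatter), a 13-fold higher number from compound 1 to compound 3 (1.12 log units; beyond the scatter) and a 160-fold higher number from compound 2 to compound 3 (2.21 log units; beyond the scatter). All three are large, yet all three lie in the chain. None touches the group that changes here, so they give neither a size nor a direction for this change. Among the compounds with values here, they show only that a single change in these compounds can move the number a long way, which argues for a wide range. No step beyond the scatter is therefore expected in this assay, and the value of compound 3, 3890 nM, remains the only anchor. The expected size of the change is a 1.2-fold higher number from compound 3 to compound 4 (0.06 log units; within the scatter). The estimate for compound 4 is 4500 nM, with an expected range of 1300 nM to 15000 nM.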

Compound 4, half-maximal inhibitory concentration: 2780 nM
Compound 4: the middle estimate sits 1.6-fold (0.21 log units) above what was measured; measured number inside the range.
By their numbers in this assay, from the lowest: compound 2; then compound 1; then compounds 4 and 3 (each within the scatter of the next).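

In this assay, phenyl in place of 2,4-dimethylphenyl on the aromatic carbon next to the ring nitrogen gives a 1.4-fold lower number from compound 3 to compound 4 (0.15 log units; within the scatter), so the aryl group at this position can be reduced to plain phenyl without a readable change while the propargyl group stays on the ring nitrogen. This is the only step shown that lies outside the chain, and unlike the large steps within the chain, it does not separate its two compounds, which suggests that the number in this small set answers to the chain far more than to these two aryl groups. No measurement shown offers an explanation for this result.

The compounds shown leave open whether the same exchange would be just as silent with the long chain of compound 2, since the aryl group has been compared only with the propargyl group in place. They also leave open whether a group of another kind on this phenyl ring, such as a methoxy group, an amine or a carboxylic acid, would move the number beyond the scatter.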